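The source may hold more compounds than are shown below. What is called first, only, known or untested is meant among the compounds shown, and "the series" means these compounds.

Measured so far:
- compound 1 `O=C1[C@@H](NS(=O)(=O)c2cc3c(Cl)nccc3s2)CCN1CCNc1ccncc1` — an assay on isolated protein for inhibition of coagulation factor X (Oryctolagus cuniculus), tested at 1 uM; a lower number here means less inhibition, a higher number more inhibition at the concentration tested (going by the name of the read-out): 39%
- compound 2 `O=C1[C@@H](NS(=O)(=O)c2ccc(-c3ccccn3)s2)CCN1Cc1cc2[nH]cccc-2n1` — this assay: 8%
- compound 3 `CC(C)(C)c1ccc(S(=O)(=O)N[C@H]2CCN(Cc3cc4[nH]cccc-4n3)C2=O)cc1` — this assay: 22%

Compound 2 stands lowest of the three numbers. Compound 3 is the nearest to it and lies higher, beyond the scatter; compound 1 lies furthest above, also beyond the scatter. Going by the values given here, no pair among the measured compounds differs in one place only, so no single-change step is available as a guide.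

Compound 4 `O=C1[C@@H](NS(=O)(=O)c2ccc(-c3ccccn3)s2)CCN1Cc1cc2cc[nH]cc-2n1` has not been measured. It differs from compound 2 by a group of 9 heavy atoms (7 carbon, 2 nitrogen; one five-membered aromatic ring with 1 hetero atom, one six-membered aromatic ring with 1 hetero atom) in place of a group of 9 heavy atoms (7 carbon, 2 nitrogen; one five-membered aromatic ring with 1 hetero atom, one six-membered aromatic ring with 1 hetero atom), on a saturated chain carbon bound to an amide-type nitrogen in a ring; the two compounds have the same atoms, joined differently, and the exchanged group sits on a saturated chain carbon bound to an amide-type nitrogen in a ring.

Among the compounds with values here, with no measured step of this kind to lean on, the change is expected to move the read-out little, in no fixed direction, and most likely not beyond the scatter. The estimated step of a number 4 percentage points higher from compound 2 to compound 4 (within the scatter) is taken as small. Compound 4 is accordingly expected to give about 12% in this assay, in a range from 0% to 35%.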

Compound 4, a percentage reported as inhibition, at one concentration (the size of the read-out at that concentration, not a potency): 17%
Compound 4: middle estimate off by 5 percentage points, on the low side; measured number inside the range.
By their numbers in this assay, from the lowest: compounds 2, 4 and 3 (each within the scatter of the next, the first and the last beyond it); then compound 1.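

This pair gives the series its first single-change reading in this assay: with the same atoms joined differently in the group on a saturated chain carbon bound to an amide-type nitrogen in a ring, the result is a number 9 percentage points higher from compound 2 to compound 4 (within the scatter). At this position, then, rearranging a group that keeps one five-membered and one six-membered aromatic ring, with the same hydrogen-bond donor and acceptor counts, does not separate the two compounds in this read-out. No measured information explains the read-out at this position.

Going by these compounds, whether a group of another kind at this position, such as a primary amine or a carboxylic acid, would shift the read-out beyond the scatter remains open. Also open, on these data alone, is whether the same rearrangement would read alike with another group on the sulfonamide side.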